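Swapping the anilino phenyl for a small thioamide-bearing chain

The source may hold more compounds than are shown below. What is called first, only, known or untested is meant among the compounds shown, and "the series" means these compounds.

In a functional assay on K562 cells (Homo sapiens) for cytotoxicity, read by MTT assay, with a stated time of 3 days (a lower number here means a stronger inhibitor, a higher number a weaker inhibitor), compound 2 `N#Cc1c(Nc2ccccc2)nc(SCc2nc3ccccc3[nH]2)nc1-c1ccccc1` gives 3.2 nM, the lowest of the two numbers measured. For the measured compounds named here, compound 1 `N#Cc1c(Cl)nc(SCc2nc3ccccc3[nH]2)nc1-c1ccccc1` gives 11.3 nM in this assay, and the one step recorded, a 3.5-fold lower number from compound 1 to compound 2 (0.55 log units; beyond the scatter), shows that what sits on this carbon of the shared core shifts the number modestly. Compound 3 `N#Cc1c(NNC(N)=S)nc(SCc2nc3ccccc3[nH]2)nc1-c1ccccc1` keeps the anilino nitrogen but changes what hangs on it: a group of 4 heavy atoms (1 carbon, 2 nitrogen, 1 sulfur; no ring) in place of a group of 6 heavy atoms (6 carbon; one six-membered aromatic ring of carbon only), on a nitrogen on an aromatic ring. Going by the values given here, no measured pair swaps groups on this nitrogen, so the only guide is that the earlier step was modest. Because compound 2 already sits at 3.2 nM, the expectation is a modest move in the weaker direction, a 6.3-fold higher number from compound 2 to compound 3 (0.80 log units; beyond the scatter), while a result within the scatter cannot be ruled out. Compound 3 is therefore estimated at 20 nM, with a range from 5 nM to 100 nM.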

Compound 3, half-maximal inhibitory concentration: 8.9 nM
Beside the measured number, compound 3's estimate is 2.2-fold (0.35 log units) above it; measured number inside the range.
By their numbers in this assay, from the lowest: compound 2; then compounds 3 and 1 (each within the scatter of the next).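

On a nitrogen on an aromatic ring, the phenyl can give way to a group with no ring at only a modest cost in this assay (a 2.8-fold higher number from compound 2 to compound 3 (0.44 log units; beyond the scatter)). The new group also brings hydrogen-bond donors that the phenyl lacks, so this position accepts two quite different groups. Against the chloro compound, however, the result is a 1.3-fold lower number from compound 1 to compound 3 (0.10 log units; within the scatter), so the gain seen with the anilino group does not carry over to this chain, and no data here give a reason for either step.

The compounds shown leave open whether the phenyl's edge comes from its ring, which a cyclohexyl ring or a simple methyl on this nitrogen would help to test. They also leave open whether the sulfur of the chain matters, which its oxygen counterpart, a semicarbazide chain, would address.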